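This account rests on a few compounds, and the source may have more. Where it says the series, first, only, none or still open, it means among the compounds named here.

Three compounds share one core and differ only in the group on the aromatic ring. Compound 1 `O=C1CSC(c2cccc(O)c2)N1CCN1CCCCC1` carries a hydroxy on that ring, and in an ADME assay on Vero cells (Chlorocebus sabaeus) for cytotoxicity, read by neutral red uptake, tested at 12.3 ug/mL (a lower number here means a stronger effect, a higher number a weaker effect of the compound at the concentration tested), compound 1 gives 100%. Compound 2 `O=C1CSC(c2ccc(O)cc2)N1CCN1CCCCC1` bears 4-hydroxyphenyl in place of 3-hydroxyphenyl, and in this assay compound 2 gives 100%, so that no change at the digits printed from compound 1 to compound 2 (within the scatter). Compound 3 `O=C1CSC(c2ccc([N+](=O)[O-])cc2)N1CCN1CCCCC1` carries a nitro instead of the hydroxy, and in this assay compound 3 gives 100%; again no change at the digits printed from compound 2 to compound 3 (within the scatter). Compound 3 therefore stands level with compounds 1 and 2 at the digits shown: every measured value sits at the same place, and neither step so far has moved the read-out beyond the scatter.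

Within the data shown here, compound 4 `Cc1ccc(C2SCC(=O)N2CCN2CCCCC2)cc1` is the next member. methyl in place of nitro on an aromatic carbon Both measured steps, the shifted hydroxy and the nitro in place of the hydroxy, left the read-out unchanged, and these are the only steps that bear on the new change. A step of no size beyond the scatter is therefore expected, no change at the digits printed from compound 3 to compound 4 (within the scatter). For compound 4 in this assay the estimate is 100%, with a range from 88% to 100%.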

Compound 4, a percentage reported as activity, at one concentration (the size of the read-out at that concentration, not a potency): 100%
Estimate against measurement, compound 4: no gap at the digits printed; the measured number falls inside the stated range.
By their numbers in this assay, from the lowest: compounds 1, 2, 3 and 4 (each within the scatter of the next).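

In this assay, the aromatic carbon now carries a different kind of group: methyl, with 1 heavy atom and 0 hydrogen-bond acceptors, replaces nitro, with 3 heavy atoms and 2 hydrogen-bond acceptors, and the outcome is no change at the digits printed from compound 3 to compound 4 (within the scatter). The comparison with the hydroxy at the same place gives no change at the digits printed from compound 2 to compound 4 (within the scatter), and the comparison with the 3-hydroxyphenyl arrangement gives no change at the digits printed from compound 1 to compound 4 (within the scatter), so among these four compounds a group made only of carbon and hydrogen sits level with groups containing oxygen or nitrogen. No supporting measurement is available to explain why the read-out stays flat across these changes.

With all four compounds level, the compounds shown leave open whether any group at this place can move the read-out at all, such as an amine, a carboxylic acid or a longer chain in place of the methyl. As far as these compounds go, the read-out also comes from a single concentration, so how these compounds compare at other concentrations remains open.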